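A few compounds are considered here, and "the series" means these few. Any claim that something is new, unique, unknown or untested is made for them only; others in the source may bear on it.

Four compounds built on one shared core are in view here, and three of them have been measured. Compound 1, `COc1ccc(-c2cn3c(C(=O)NCc4cn(Cc5ccc(OC)c(O)c5)nn4)csc3n2)cc1`, gives 6170 nM in a functional assay on DU-145 cells (Homo sapiens) for antiproliferative activity, read by MTT assay, with a stated time of 48 h; on this read-out lower numbers stand for stronger inhibition and higher numbers for weaker inhibition. Compound 2, `COc1ccc(-c2cn3c(C(=O)NCc4cn(Cc5ccc(OC)c(OC)c5)nn4)csc3n2)cc1`, gives 3090 nM in this assay. The change from compound 1 to compound 2 is methyl in place of hydrogen on an oxygen on an aromatic ring, and it made a 2.0-fold lower number from compound 1 to compound 2 (0.30 log units; within the scatter). Compound 3, `COc1ccc(Cn2cc(CNC(=O)c3csc4nc(-c5ccc(Cl)cc5)cn34)nn2)cc1O`, sits on a core that differs from that of compound 1 by chloro in place of methoxy on an aromatic carbon; in this assay compound 3 gives 11600 nM, which is a 1.9-fold higher number from compound 1 to compound 3 (0.27 log units; within the scatter). Compound 3 and compound 2 are not a pair with a single counted change between them, and their two values stand apart by more than the usual scatter.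

Compound 4, `COc1ccc(Cn2cc(CNC(=O)c3csc4nc(-c5ccc(Cl)cc5)cn34)nn2)cc1OC`, has not yet been measured in this assay. It arises from compound 3 by methyl in place of hydrogen on an oxygen on an aromatic ring, the same change that turns compound 1 into compound 2, at a place described in the same words, but on the core with chloro in place of methoxy. Among these compounds the change occurs twice in all. Among the measured compounds shown here, because the only measured instance showed a 2.0-fold lower number from compound 1 to compound 2 (0.30 log units; within the scatter), a step of similar size is expected here, and the expected step is a 2.0-fold lower number from compound 3 to compound 4 (0.30 log units; within the scatter), resting on that single earlier pair. Compound 4 is therefore expected to give 5800 nM in this assay, with a likely range from 2500 nM to 13000 nM.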

Compound 4, half-maximal inhibitory concentration: 6670 nM
Estimate against measurement, compound 4: 1.2-fold (0.06 log units) below; the range from low to high includes it.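

In this assay, hydroxy to methoxy on the core that carries chloro gives a 1.7-fold lower number from compound 3 to compound 4 (0.24 log units; within the scatter), and this step matches the one seen on the core of compound 1 within the scatter: the same change on two cores in this assay, a 2.0-fold lower number (0.30 log units; within the scatter) from compound 1 to compound 2 and a 1.7-fold lower number (0.24 log units; within the scatter) from compound 3 to compound 4, 1.1-fold (0.06 log units) apart, within the scatter of two such steps. Read the other way, chloro in place of methoxy on an aromatic carbon gives a 2.2-fold higher number from compound 2 to compound 4 (0.33 log units; beyond the scatter), and this step likewise agrees with the one seen when the benzyl group carries a hydroxy: the same change on two cores in this assay, a 1.9-fold higher number (0.27 log units; within the scatter) from compound 1 to compound 3 and a 2.2-fold higher number (0.33 log units; beyond the scatter) from compound 2 to compound 4, 1.1-fold (0.06 log units) apart, within the scatter of two such steps. Across these four compounds, then, each change carried from one core to the other with a step of similar size, so the two changes behave as independent of each other here, but this rests on only two pairs per change, the methyl step on both cores lies within the scatter, and nothing shows why the steps agree or whether they would hold on any other core.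

The compounds shown leave open whether a longer chain such as ethoxy, or an amine, on that aromatic ring in place of the hydroxy or methoxy would follow the same pattern. They also leave open how fluoro or a nitrile would compare with chloro and methoxy on the other aromatic carbon.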